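Swapping cyano for methyl: the step to compound 3

This account rests on a few compounds, and the source may have more. Where it says the series, first, only, none or still open, it means among the compounds named here.

- compound 1 (`C[C@@H]1CC(c2cnc3c(C#N)nn([C@H](C)c4ccc(Cl)cc4Cl)c3n2)=CC[C@@H]1N1CCC[C@H]1CO`) gives 81%
- compound 2 (`C[C@@H]1CC(c2cnc3c(C#N)nn([C@H](C)c4ccc(Cl)cc4Cl)c3n2)=CC[C@@H]1N1CCC[C@H]1C(C)(C)O`) gives "not determined" (no result reported)

Among the compounds with values here, in an ADME assay on cells (Hepatocyte, Homo sapiens) for metabolic stability, read by LC-MS, with a stated time of 60 min (on this read-out higher numbers stand for a more stable compound and lower numbers for a less stable compound), compound 1 gives 81%, the only number so far, so it cannot yet be ranked against anything. Compound 3 (`Cc1nn([C@H](C)c2ccc(Cl)cc2Cl)c2nc(C3=CC[C@H](N4CCC[C@H]4CO)[C@H](C)C3)cnc12`) differs from compound 1 by methyl in place of cyano on an aromatic carbon. Within the data shown here, no measured pair shows what this change does. A moderate fall in this assay is expected, although a step within the usual scatter remains possible. The expected size is a number 13 percentage points lower from compound 1 to compound 3 (beyond the scatter). For compound 3 the estimate is 68%, with an expected range of 45% to 85%.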

Compound 3, percent of the compound remaining: 99%
For compound 3 the middle estimate is 31 percentage points below the measured one, and the stated range ends below it.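

In this assay, within the data shown here, the only readable step at this position is a number 18 percentage points higher from compound 1 to compound 3 (beyond the scatter). On this aromatic carbon of the five-membered ring, methyl in place of cyano therefore raises the percent remaining, and the nitrile is not needed for the high value of compound 1 81%. Nothing at hand explains this step.

On these data alone, whether ethyl, chlorine or a primary amide on the same carbon would behave like methyl stays open. Steps involving compound 2 cannot be read, so whether the rise carries over to its side chain also stays open.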